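Solubility notes: from compound 1 to compound 3

The source may hold more compounds than are shown below. What is called first, only, known or untested is meant among the compounds shown, and "the series" means these compounds.

Among the compounds with values here, in a physicochemical assay for solubility, in phosphate buffer, at pH 7.4 (a lower number here means a less soluble compound, a higher number a more soluble compound), compound 1 (`C[C@H](C(=O)N(Cc1ccc(C2CCCCC2)cc1)c1ccc(C(=O)O)c(O)c1)N(C)S(=O)(=O)c1c(F)c(F)c(F)c(F)c1F`) gives 127 ug/mL, the higher of the two numbers so far. Compound 2 (`CN(CC(=O)N(Cc1ccc(C2CCCCC2)cc1)c1ccc(C(=O)O)cc1)S(=O)(=O)c1c(F)c(F)c(F)c(F)c1F`) gives 7.6 ug/mL, and the gap between them lies beyond the scatter. These two compounds differ in more than one place, so their gap does not isolate any single change.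

Compound 3 (`C[C@H](C(=O)N(Cc1ccc(C2CCCCC2)cc1)c1ccc(C(=O)NO)cc1F)N(C)S(=O)(=O)c1c(F)c(F)c(F)c(F)c1F`) carries 2-fluoro-4-(hydroxycarbamoyl)phenyl in place of 4-carboxy-3-hydroxyphenyl on an amide-type nitrogen. Within the data shown here, no measured pair covers this replacement, so the expectation rests on little. Compound 2, at 7.6 ug/mL, shows only that this series can read well under compound 1. In this assay, the estimate is a 16-fold lower number from compound 1 to compound 3 (1.20 log units; beyond the scatter), an expected fall beyond the scatter. For compound 3 the expected value is 8 ug/mL, with an estimated range of 2 ug/mL to 30 ug/mL.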

Compound 3, solubility: 4.7 ug/mL
For compound 3 the middle estimate is 1.7-fold (0.23 log units) above the measured one, within the range that was stated.
By their numbers in this assay, from the lowest: compounds 3 and 2 (each within the scatter of the next); then compound 1.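

Within the data shown here, on the amide-type nitrogen whose other neighbours are a carbonyl carbon and a saturated chain carbon, the series now has its only single-place comparison. In this assay, 2-fluoro-4-(hydroxycarbamoyl)phenyl in place of 4-carboxy-3-hydroxyphenyl gives a 27-fold lower number from compound 1 to compound 3 (1.43 log units; beyond the scatter) and that step is large, so in this one pair the number depends strongly on which group sits at this place, although both groups count the same hydrogen-bond donors and acceptors. No measurement at hand bears on the cause of the fall.

The step joins several edits in one group, so the fluorine and the hydroxycarbamoyl group cannot be read apart from these compounds. From the compounds shown here alone, how an aminomethyl group or a primary carboxamide would read at this place also remains open.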